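Working notes on the aryl position of the shared core

A few compounds are considered here, and "the series" means these few. Any claim that something is new, unique, unknown or untested is made for them only; others in the source may bear on it.

Measured in a functional assay for antagonist activity at Adrenergic receptor alpha-1 (Rattus norvegicus); a higher number here means weaker binding, a lower number tighter binding:
- compound 1 `COc1cccc(OC)c1OCCNC[C@H]1Oc2ccccc2O[C@@H]1C(C)C`: 269 nM
- compound 2 `COc1cccc(OC)c1OCCNC[C@H]1Oc2ccccc2O[C@@H]1c1ccc(Cl)cc1`: 7.08 nM
- compound 3 `CCc1ccc([C@H]2Oc3ccccc3O[C@@H]2CNCCOc2c(OC)cccc2OC)cc1`: 15.1 nM

Compound 3 stands second of the three numbers in this assay. It sits close to compound 2, separated by a 2.1-fold higher number from compound 2 to compound 3 (0.33 log units; beyond the scatter), and far from compound 1, as an 18-fold lower number from compound 1 to compound 3 (1.25 log units; beyond the scatter) shows. The largest movement in the set comes from swapping the isopropyl for an aryl group, seen in a 38-fold lower number from compound 1 to compound 2 (1.58 log units; beyond the scatter) and in an 18-fold lower number from compound 1 to compound 3 (1.25 log units; beyond the scatter); the choice of substituent on that aryl ring, in a 2.1-fold higher number from compound 2 to compound 3 (0.33 log units; beyond the scatter), moves the number only modestly.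

Compound 4 `COc1cccc(OC)c1OCCNC[C@H]1Oc2ccccc2O[C@@H]1c1ccc(O)cc1` keeps the aryl group and changes only its substituent: hydroxy in place of ethyl on an aromatic carbon. Among the compounds with values here, the one measured step that bears on this position is a 2.1-fold higher number from compound 2 to compound 3 (0.33 log units; beyond the scatter), which was modest. Within the data shown here, no compound yet carries a hydrogen-bond donor at that place, so the direction is not fixed by the data. The expected step in this assay is therefore small, most likely a somewhat higher number than compound 3, about a 1.7-fold higher number from compound 3 to compound 4 (0.22 log units; within the scatter). Compound 4 is estimated at 25 nM, with a range from 7 nM to 90 nM.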

Compound 4, dissociation constant: 14.5 nM
Compound 4: the middle estimate sits 1.7-fold (0.24 log units) above what was measured; measured number inside the range.
By their numbers in this assay, from the lowest: compound 2; then compounds 4 and 3 (each within the scatter of the next); then compound 1.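

Within the data shown here, at the place para to a large group, a hydrogen-bond donor now appears for the first time, and in this assay the step to it gives a 1.0-fold lower number from compound 3 to compound 4 (0.02 log units; within the scatter), so hydroxy and ethyl cannot be told apart here even though they differ in heavy atoms and in hydrogen-bond donors and acceptors. Chloro now stands apart from two different substituents rather than one, since a 2.0-fold higher number from compound 2 to compound 4 (0.31 log units; beyond the scatter) is modest like a 2.1-fold higher number from compound 2 to compound 3 (0.33 log units; beyond the scatter), while a 19-fold lower number from compound 1 to compound 4 (1.27 log units; beyond the scatter) shows that the large step from isopropyl to an aryl group also holds with hydroxy on the ring, as it did with chloro and ethyl. Nothing available accounts for any of these steps.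

On these data alone, whether this flat reading between hydroxy and ethyl extends to an amine or a carboxylic acid at this place remains open, as does whether a bromo or a trifluoromethyl group would read like chloro in compound 2. A methoxy group, which keeps the oxygen but lacks the hydroxy hydrogen, would show whether that hydrogen matters at all next to compound 4.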